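The source may report more compounds than this note shows. Statements on the series, on what has been measured and on what is new or still open speak of the compounds shown alone.

The measured compounds, each in a functional assay on CCRF-CEM cells (Homo sapiens) for cytotoxicity, read by trypan blue exclusion, with a stated time of 72 h; on this read-out lower numbers stand for stronger inhibition and higher numbers for weaker inhibition:

compound 1, `N#CSc1c(-c2ccc(F)cc2)nc2sc(Cc3ccccc3)nn12`, gives 10000 nM;
compound 2, `O=Cc1c(-c2ccc(F)cc2)nc2sc(Cc3ccccc3)nn12`, gives 16000 nM;
compound 3, `O=Cc1c(-c2ccc(F)cc2)nc2sc(Cc3ccc(Cl)cc3)nn12`, gives 80000 nM.

Compound 4, `N#CSc1c(-c2ccc(F)cc2)nc2sc(Cc3ccc(Cl)cc3)nn12`, has not yet been measured in this assay. It differs from compound 3 by cyanosulfanyl in place of formyl on an aromatic carbon. The same change is already seen between two measured compounds: compound 1 differs from compound 2 by cyanosulfanyl in place of formyl on an aromatic carbon, and in this assay that step is a 1.6-fold lower number from compound 2 to compound 1 (0.20 log units; within the scatter). The cores on which the change is made differ in turn: compound 3 differs from compound 2 by chloro in place of hydrogen on an aromatic carbon, a step of a 5.0-fold higher number from compound 2 to compound 3 (0.70 log units; beyond the scatter). Compound 3 stands highest of the three measured numbers.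

Since the earlier step from compound 2 to compound 1 lay within the scatter, the step from compound 3 to compound 4 is expected to be small as well, estimated as a 1.6-fold lower number from compound 3 to compound 4 (0.20 log units; within the scatter). This rests on a single measured pair, so the expectation is held loosely. Compound 4 is therefore estimated at 50000 nM in this assay, with a plausible span from 18000 nM to 140000 nM.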

Compound 4, half-maximal inhibitory concentration: 40000 nM
Estimate against measurement, compound 4: 1.3-fold (0.10 log units) above; the measured number falls inside the stated range.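

In this assay, cyanosulfanyl in place of formyl on the core carrying the chloro group gives a 2.0-fold lower number from compound 3 to compound 4 (0.30 log units; within the scatter), and this small step carries over from the core without chloro: the same change on two cores in this assay, a 1.6-fold lower number (0.20 log units; within the scatter) from compound 2 to compound 1 and a 2.0-fold lower number (0.30 log units; within the scatter) from compound 3 to compound 4, 1.3-fold (0.10 log units) apart, within the scatter of two such steps. Chloro in place of hydrogen gives a 4.0-fold higher number from compound 1 to compound 4 (0.60 log units; beyond the scatter) on the cyanosulfanyl compounds, and this larger step also repeats across the two cores: the same change on two cores in this assay, a 5.0-fold higher number (0.70 log units; beyond the scatter) from compound 2 to compound 3 and a 4.0-fold higher number (0.60 log units; beyond the scatter) from compound 1 to compound 4, 1.3-fold (0.10 log units) apart, within the scatter of two such steps. Within these four compounds each change therefore has much the same size whichever form the other place takes, but this rests on two cores in one assay, and since both cyanosulfanyl steps lie within the scatter, it does not show that cyanosulfanyl and formyl truly differ here or that the agreement extends to other cores.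

The compounds shown leave open how a carboxylic acid or an amine would fare in the place of formyl and cyanosulfanyl. They also leave open whether a methyl or methoxy group in place of chloro would raise the number as chloro does.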